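This account rests on a few compounds, and the source may have more. Where it says the series, first, only, none or still open, it means among the compounds named here.

Measured so far:
- Compound 1 `CCn1c(C(=O)N[C@@H](CC(=O)OC)C(=O)OC)ccc1C(CC)(CC)c1ccc(OCS(=O)(=O)c2ccccc2)c(C)c1`: > 50000 nM, a limit of the assay and not a number
- Compound 2 `CCN(CC)CCNC(=O)c1ccc(C(CC)(CC)c2ccc(OCS(=O)(=O)c3ccccc3)c(C)c2)n1CC`: 6270 nM
- Compound 3 `CCn1c(C(=O)N[C@@H](C(=O)O)C(C)C)ccc1C(CC)(CC)c1ccc(OCS(=O)(=O)c2ccccc2)c(C)c1`: 13900 nM

In a functional assay on BXPC-3 cells (Homo sapiens) for antiproliferative activity, read by MTT assay, with a stated time of 24 h (on this read-out higher numbers stand for weaker inhibition and lower numbers for stronger inhibition), compound 2 gives 6270 nM, the lower of the two true numbers. Compound 4 `CCN(CC)CCNC(=O)c1ccc(C(CC)(CC)c2ccc(OCSc3ccccc3)c(C)c2)n1CC` keeps the amide side chain of compound 2 but carries phenylsulfanyl in place of phenylsulfonyl on a saturated chain carbon bound to an oxygen on an aromatic ring. Among the measured compounds shown here, no measured step touches this place. All three change the group on the amide-type nitrogen: an at least 7.9-fold lower number from compound 1 to compound 2 (0.90 log units; beyond the scatter), an at least 3.5-fold lower number from compound 1 to compound 3 (0.55 log units; beyond the scatter) and a 2.2-fold higher number from compound 2 to compound 3 (0.35 log units; beyond the scatter). For the measured compounds named here, they show only that single changes here can matter modestly, so the starting point stays compound 2 at 6270 nM, with no direction favoured. An estimated 1.0-fold lower number from compound 2 to compound 4 (0.02 log units; within the scatter) is expected, with no step beyond the scatter. For compound 4 the estimate is 6000 nM, with an expected range from 2000 nM to 20000 nM.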

Compound 4, half-maximal inhibitory concentration: 5670 nM
Beside the measured number, compound 4's estimate is 1.1-fold (0.02 log units) above it, within the range that was stated.
By their numbers in this assay, from the lowest: compounds 4 and 2 (each within the scatter of the next); then compound 3. At a limit, above all of these: compound 1.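

Phenylsulfanyl in place of phenylsulfonyl is the first measured change at this place, and in this assay it gives a 1.1-fold lower number from compound 2 to compound 4 (0.04 log units; within the scatter). With the 2-(diethylamino)ethyl group kept on the amide-type nitrogen, the oxygens of phenylsulfonyl can therefore go without a shift beyond the scatter. Nothing shown gives a reason for this result. Going by these compounds, whether the same swap reads alike with 1-carboxy-2-methylpropyl on that nitrogen remains open. So does the effect of an amine on the phenyl ring, or of a longer chain at this place.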